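The source may hold more compounds than are shown below. What is called first, only, known or untested is meant among the compounds shown, and "the series" means these compounds.

Measured so far:
- compound 1, `N[C@@H](COP(=O)(O)OC[C@H]1OCC=C[C@H]1OC(=O)CCc1ccccc1OCc1cccc(Oc2ccccc2)c1)C(=O)O`: 0.86
- compound 2, `CCCCCCCCCCCOc1ccccc1CCC(=O)OCc1ccc(OP(=O)(O)OC[C@H](N)C(=O)O)cc1`: "not active" (no number reported)

In an assay on HEK293-A cells with probable G-protein coupled receptor 34 (Mus musculus) as the target, with a stated time of 1.5 h (on this read-out higher numbers stand for larger maximal responses and lower numbers for smaller maximal responses), compound 1 gives 0.86. Compound 2 is reported in this assay only as "not active" (no number reported), with no number attached, so compound 1 carries the only figure in the series and no order between the two can be stated. Compound 3, `N[C@@H](COP(=O)(O)OC[C@H]1OCC=C[C@@H]1OC(=O)CCc1ccccc1OCc1cccc(Oc2ccccc2)c1)C(=O)O`, has not been measured. It differs from compound 1 by the two compounds have the same atoms and bonds; at least one stereo element is drawn with a configuration in one of them and without one in the other: 1 of 4 stereo elements differ; a stereocentre at a saturated ring carbon is drawn R in compound 1 and S in compound 3. For the measured compounds named here, no step between two measured compounds is available, so this change of configuration has no measured counterpart to calibrate it against. With only the figure for compound 1 to start from, the expectation is a decrease beyond the usual scatter, taken with a wide margin. The expected step from compound 1 to compound 3 in this assay is a number 0.26 lower from compound 1 to compound 3 (beyond the scatter). For compound 3 the estimated value in this assay is 0.6, within 0.2 to 0.95.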

Compound 3, intrinsic activity: the largest response reached, as a fraction of the reference agonist's: "not active" (no number reported)
Compound 3: no number reported; there is nothing to compare the estimate with.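

In this assay, for the compounds shown here, compound 3 is reported only as not active, without a number, so no step from compound 1 at 0.86 can be read. The compounds shown leave open the size of any effect of the saturated ring carbon's configuration, drawn R in compound 1 and S in compound 3, on the maximal response.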